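The source may report more compounds than this note shows. Statements on the series, on what has been measured and on what is new or still open speak of the compounds shown alone.

Measured compounds:
- Compound 1, `CCN1CCN(c2cc(C)c3cc(NC(=O)c4ccc[nH]4)ccc3n2)CC1`: 14700 nM
- Compound 2, `Cc1cc(NCCN(C)C)nc2ccc(NC(=O)c3ccc(Cl)c(Cl)c3)cc12`: 2550 nM
- Compound 3, `Cc1cc(N2CCN(C)CC2)nc2ccc(NC(=O)c3ccc(Cl)c(Cl)c3)cc12`: 3000 nM

All three were tested in a functional assay on MCF7 cells (Homo sapiens) for antiproliferative activity, read by MTT assay, with a stated time of 72 h; a higher number here means a weaker inhibitor, a lower number a stronger inhibitor. Compound 1 stands at the highest number of the three; compound 3 is nearest, with a lower number, and compound 2 is furthest, also lower. Among the measured compounds shown here, the only one-point step among the measured compounds is a 1.2-fold higher number from compound 2 to compound 3 (0.07 log units; within the scatter), which changes the amine-bearing group on the shared core and leaves the amide end untouched.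

The unmeasured compound 4, `CCN1CCN(c2cc(C)c3cc(NC(=O)c4cc5ccccc5[nH]4)ccc3n2)CC1`, differs from compound 1 in that amide end: 1H-indol-2-yl in place of 1H-pyrrol-2-yl on a carbonyl carbon. For the measured compounds named here, no measured step alters that part of the molecule, so the step from compound 2 to compound 3 does not bear on it directly. What the numbers do show is that compounds 2 and 3, which carry a larger aromatic group on the carbonyl carbon than compound 1 does, both give lower numbers than compound 1, though they also differ from compound 1 elsewhere. On that basis a modest move toward a lower number is expected for compound 4, with the estimated step of a 2.9-fold lower number from compound 1 to compound 4 (0.47 log units; beyond the scatter). The value for compound 4 in this assay is expected near 5000 nM, within a range from 1500 nM to 15000 nM.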

Compound 4, half-maximal inhibitory concentration: 2950 nM
Estimate against measurement, compound 4: 1.7-fold (0.23 log units) above; the range from low to high includes it.
By their numbers in this assay, from the lowest: compounds 2, 4 and 3 (each within the scatter of the next); then compound 1.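

In this assay the amide end of the molecule proves able to move the number: 1H-indol-2-yl in place of 1H-pyrrol-2-yl on the carbonyl carbon gives a 5.0-fold lower number from compound 1 to compound 4 (0.70 log units; beyond the scatter) with the rest of the structure unchanged. Among the compounds shown here, the earlier step touched only the amine-bearing group, so this is the first direct reading at this position. The incoming group keeps the five-membered aromatic ring with its nitrogen and adds a six-membered aromatic ring of carbon only, while the count of hydrogen-bond donors stays the same. Nothing available explains why this exchange lowers the number.

One pair of compounds cannot show whether the hydrogen on the ring nitrogen matters here, a question that 1-methyl-1H-indol-2-yl, with a methyl group on that nitrogen, or benzofuran-2-yl, with an oxygen in its place, could address. As far as these compounds go, it also remains open whether 1H-indol-2-yl would give a step of similar size on a compound carrying (2-(dimethylamino)ethyl)amino instead of the 4-ethylpiperazin-1-yl group.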